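The source may report more compounds than this note shows. Statements on the series, on what has been measured and on what is new or still open speak of the compounds shown alone.

Three compounds built on the shared core were tested in a functional assay on PC-3 cells (Homo sapiens) for inhibition, read by MTT assay, with a stated time of 48 h; on this read-out lower numbers stand for stronger inhibition and higher numbers for weaker inhibition. Compound 1 `C=C1CC[C@@H]2[C@](C)(CO)[C@H](O)CC[C@@]2(C)[C@@H]1CC(Sc1ccc([N+](=O)[O-])cc1)C1=CCOC1=O` gives 17000 nM in this assay. Compound 2 `C=C1CC[C@@H]2[C@](C)(CO)[C@H](O)CC[C@@]2(C)[C@@H]1C/C=C1/C(=O)OC[C@H]1OC(=O)CSc1ccc(C)cc1` gives 27000 nM in this assay. Compound 3 `C=C1CC[C@@H]2[C@](C)(CO)[C@H](O)CC[C@@]2(C)[C@@H]1C/C=C1/C(=O)OC[C@H]1OC(=O)CSc1cccs1` gives 18000 nM in this assay. The numbers of compound 3, compound 1 and compound 2 differ from one another only within the usual scatter, so no order among the three can be read from them. For the measured compounds named here, the one single-point step in the set, a 1.5-fold lower number from compound 2 to compound 3 (0.18 log units; within the scatter), is likewise within the scatter.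

Compound 4 `C=C1CC[C@@H]2[C@](C)(CO)[C@H](O)CC[C@@]2(C)[C@@H]1C/C=C1/C(=O)OC[C@H]1OC(=O)CCCSc1ccccn1` has not yet been measured in this assay. It differs from compound 3 by 2-((pyridin-2-yl)sulfanyl)ethyl in place of (thiophen-2-yl)sulfanyl on a saturated chain carbon bound to a carbonyl carbon. Going by the values given here, no measured step touches this kind of change: the step from compound 2 to compound 3 exchanged only the aromatic ring on the sulfur, whereas here the chain between the carbonyl and the sulfur is lengthened and the ring is changed at the same time. Among the compounds with values here, with the only comparable step inside the scatter, the account expects for compound 4 a number in this assay of about 20000 nM, with a range from 8000 nM to 50000 nM, and therefore an expected step of a 1.1-fold higher number from compound 3 to compound 4 (0.05 log units; within the scatter), which is not expected to go beyond the scatter in either direction.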

Compound 4, half-maximal inhibitory concentration: 14000 nM
The estimate for compound 4 lay 1.4-fold (0.15 log units) above the measured number; the measured number falls inside the stated range.
By their numbers in this assay, from the lowest: compounds 4, 1, 3 and 2 (each within the scatter of the next).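

Compound 4 shows that the position on a saturated chain carbon bound to a carbonyl carbon takes a larger change than the exchange of one aromatic ring on the sulfur: in this assay, 2-((pyridin-2-yl)sulfanyl)ethyl in place of (thiophen-2-yl)sulfanyl gives a 1.3-fold lower number from compound 3 to compound 4 (0.11 log units; within the scatter) and so leaves the number within the scatter. The comparison with the (4-methylphenyl)sulfanyl compound reads the same way, with a 1.9-fold lower number from compound 2 to compound 4 (0.29 log units; within the scatter) also staying within the scatter, so the added chain atoms and the pyridin-2-yl ring together move the number by no more than the earlier exchange of rings did. Nothing available here explains this result or bears on it.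

The chain and the ring changed together, so the compounds shown leave open what each contributes alone, as a pyridin-2-yl ring on the original short chain or a thiophen-2-yl ring on the longer one would tell. They also leave open whether a quite different end group on this chain, such as a primary amine or a carboxylic acid in place of the aromatic ring and its sulfur, would carry the number beyond the scatter in either direction.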